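A few compounds are considered here, and "the series" means these few. Any claim that something is new, unique, unknown or untested is made for them only; others in the source may bear on it.

Measured in an assay on isolated protein for inhibition of Rho-associated protein kinase 1 (Homo sapiens), read by scintillation counting, radiometric assay and 33P incorporation, with a stated time of 40 min, in the presence of a further agent that is not named here; a lower number here means a stronger inhibitor, a higher number a weaker inhibitor:
compound 1 , `CN(C)c1ccc(C(=O)Nc2cccc(NC(=O)COc3ccc4c(c3)CCC(=O)N4)c2)cc1`, gives > 10000 nM, which is a limit of the assay.
compound 2 , `O=C(COc1ccc2c(=O)ccoc2c1)Nc1cccc(NC(=O)c2ccc(F)cc2)c1`, gives 129 nM.
compound 3 , `CC(C)(C)c1ccc(S(=O)(=O)Nc2cccc(NC(=O)COc3ccc4c(=O)ccoc4c3)c2)cc1`, gives > 10000 nM, which is a limit of the assay.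

Going by the values given here, compound 2 therefore holds the only number in this assay among the three compounds measured; the other two values are limits, and the limit of > 10000 nM in this assay, at which 2 of the 3 values shown sit, is where both of them sit. Among the compounds with values here, no pair of measured compounds differs in a single place, so no measured step is available to lean on.

Compound 4 , `NCc1ccc(C(=O)Nc2cccc(NC(=O)COc3ccc4c(=O)ccoc4c3)c2)cc1`, has not yet been measured in this assay. It differs from compound 2 as follows: aminomethyl in place of fluoro on an aromatic carbon.

Within the data shown here, with no measured step in hand, the expectation for compound 4 rests on compound 2 alone, which gives 129 nM in this assay. The change sits on a six-membered aromatic ring of carbon only and exchanges a single heavy atom for two; a step in this assay of modest size is expected, more likely toward a stronger inhibitor than a weaker one, though a step within the scatter would not surprise. The step from compound 2 to compound 4 that this estimate means is a 2.2-fold lower number from compound 2 to compound 4 (0.33 log units; beyond the scatter), an expected value only. For compound 4 the estimate in this assay is 60 nM, with a range from 15 nM to 300 nM.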

Compound 4, half-maximal inhibitory concentration: 532 nM
Estimate against measurement, compound 4: 8.9-fold (0.95 log units) below; measured number above the stated range.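

In this assay, going by these compounds alone, exchanging 4-fluorophenyl for 4-(aminomethyl)phenyl gives a 4.1-fold higher number from compound 2 to compound 4 (0.62 log units; beyond the scatter), the only step so far between compounds that differ in one place. This shows that the position para to the large group responds to what it carries, while the change is still compatible with a measured inhibition: compound 4 gives a number, 532 nM, and not a limit of the assay. The compounds shown offer no measured basis for a cause of this step.

Going by these compounds, it remains open whether the step follows the amine itself or the added carbon, and a methyl group, a longer chain ending in an amine, or a carboxylic acid at the same position would begin to separate these readings. Compound 1 and compound 3 each differ from compound 2 in more than one place, so neither says anything about this position, and one step cannot show whether the same change would act alike on another core.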